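A Hydroxy Added Where Both Neighbours Are Inactive

The source may report more compounds than this note shows. Statements on the series, on what has been measured and on what is new or still open speak of the compounds shown alone.

Compound 1 `COc1cc(C(=O)O[C@@H]2C[C@](C)(O)[C@H]3[C@H](O[C@@H]4O[C@H](CO)[C@@H](O)[C@H](O)[C@H]4O)OC=C[C@H]32)cc(OC)c1O[C@@H]1O[C@@H](C)[C@H](O)[C@@H](O)[C@H]1O` gives > 10000 nM in a functional assay on BGC-823 cells (Homo sapiens) for cytotoxicity, read by MTT assay, with a stated time of 4 days; a higher number here means a weaker inhibitor, a lower number a stronger inhibitor; this is a limit of the assay, not a number.
Compound 2 `CC(/C=C/[C@@]1(O)C(C)(C)CCC[C@@]1(C)O)=C\C(=O)O[C@@H]1C[C@](C)(O)[C@H]2[C@H](O[C@@H]3O[C@H](CO)[C@@H](O)[C@H](O)[C@H]3O)OC=C[C@H]21` gives > 10000 nM in this assay; this too is a limit, not a number.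

Both measured compounds share the same glycoside core and differ only in the acid joined to it through the ester. Neither reaches a measurable value: compound 2 stands at the limit, and it is not alone there, because of the limit of > 10000 nM in this assay, at which 2 of the 2 values shown sit. Going by the values given here, no step between two measured compounds exists here, so nothing measured tells how a small change on the acid part moves the read-out.

Compound 3 `CC(/C=C/[C@@]1(O)C(C)(C)C[C@H](O)C[C@@]1(C)O)=C\C(=O)O[C@@H]1C[C@](C)(O)[C@H]2[C@H](O[C@@H]3O[C@H](CO)[C@@H](O)[C@H](O)[C@H]3O)OC=C[C@H]21` differs from compound 2 by one change: hydroxy in place of hydrogen on a saturated ring carbon. The rest of the molecule is unchanged.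

With both known values sitting at the limit, the expected step is none beyond the scatter, and compound 3 is expected to return a limit as well, a step that the limit leaves unreadable from compound 2 to compound 3. For compound 3 the estimate in this assay is therefore 15000 nM, with a range from 8000 nM to 40000 nM.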

Compound 3, half-maximal inhibitory concentration: > 10000 nM
Compound 3: only a limit was reported; the forecaster's own chance of this, stated with the estimate: 85%; the middle value is on the limit's open side.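

No size can be read for the step from compound 2 to compound 3, hydroxy in place of hydrogen on a saturated ring carbon, as neither compound has a number in this assay. All the compounds shown stand at one limit: the limit of > 10000 nM in this assay, at which 3 of the 3 values shown sit.

The compounds shown leave open which change to the acid part, if any, would give a measurable value.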